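The source may hold more compounds than are shown below. What is called first, only, known or untested is meant among the compounds shown, and "the series" means these compounds.

In a functional assay on MCF7 cells (Homo sapiens) for inhibition, read by MTT assay, with a stated time of 72 h (on this read-out higher numbers stand for weaker inhibition and lower numbers for stronger inhibition), compound 1 `C=C(Br)C(=O)Nc1cccc(/C=C/C(=O)Nc2ccc(C)cc2)c1` gives 2500 nM and compound 2 `C=C(Br)C(=O)Nc1cccc(/C=C/C(=O)Nc2ccc(OC)cc2)c1` gives 2500 nM, which is no change at the digits printed from compound 1 to compound 2 (within the scatter). Compound 3 `C=C(Br)C(=O)Nc1cccc(/C=C/C(=O)Nc2ccc(OCC)cc2)c1` gives 5500 nM, the highest of the three numbers and so the weakest inhibition of the set. The steps that reach it are a 2.2-fold higher number from compound 1 to compound 3 (0.34 log units; beyond the scatter) and a 2.2-fold higher number from compound 2 to compound 3 (0.34 log units; beyond the scatter).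

Compound 4 `C=C(Br)C(=O)Nc1cccc(/C=C/C(=O)Nc2ccc(OC(F)(F)F)cc2)c1` has not yet been measured. It carries trifluoromethyl in place of ethyl on an oxygen on an aromatic ring. Among the compounds with values here, no measured compound contains fluorine, so the direction of the change is poorly defined. The closest guide is the change on that same oxygen, a 2.2-fold higher number from compound 2 to compound 3 (0.34 log units; beyond the scatter), and the other changes at this group were no larger. A step of similar or smaller size is therefore expected, with a slight lean back towards the two lower numbers. The estimated step is a 1.6-fold lower number from compound 3 to compound 4 (0.20 log units; within the scatter), which would stay within the scatter. Compound 4 is expected to give about 3500 nM, with an estimated range of 1500 nM to 7500 nM.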

Compound 4, half-maximal inhibitory concentration: 43300 nM
Compound 4: middle estimate off by 12-fold (1.09 log units), on the low side, outside the stated range (above it).
By their numbers in this assay, from the lowest: compounds 1 and 2 (each within the scatter of the next); then compound 3; then compound 4.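

In this assay, within the data shown here, this position on the aromatic ring shows a much sharper response than the earlier compounds revealed: trifluoromethyl in place of ethyl on the oxygen gives a 7.9-fold higher number from compound 3 to compound 4 (0.90 log units; beyond the scatter), larger than any step among the first three compounds. Measured against the methyl on the oxygen of compound 2, the change is a 17-fold higher number from compound 2 to compound 4 (1.24 log units; beyond the scatter), and replacing the methyl on the aromatic carbon of compound 1 with trifluoromethoxy gives a 17-fold higher number from compound 1 to compound 4 (1.24 log units; beyond the scatter), leaving compound 4 the weakest inhibitor of the set. Nothing available explains this loss of inhibition.

On these data alone, whether a difluoromethyl group on that oxygen would give a number closer to compound 2 or to compound 4 remains open. Also open, as far as these compounds go, is how an amine or a chlorine on the same aromatic carbon would compare with the trifluoromethoxy group.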